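The source may report more compounds than this note shows. Statements on the series, on what has been measured and on what is new or still open speak of the compounds shown alone.

The measured compounds:
compound 1 `CCC(C(=O)N1CCN(c2ccc(C(F)(F)F)cc2)CC1)N1C(=O)CCC1=O` gives 0%
compound 2 `CCC(C(=O)N1CCN(c2cccc(C)c2)CC1)N1C(=O)CCC1=O` gives 75%
compound 3 `CCC(C(=O)N1CCN(c2cccc(Cl)c2)CC1)N1C(=O)CCC1=O` gives 100%

These three share one core and differ only in the group on the amine nitrogen in the ring. In a functional assay on the whole organism (strain Swiss) with Mus musculus as the target, in the maximal electroshock model, with a stated time of 1 h, at a dose of 300 mg/kg by the intraperitoneal route (a higher number here means a stronger effect of the compound at the dose given, a lower number a weaker effect), compound 3 stands highest of the three numbers; its nearest neighbour is compound 2, and the furthest is compound 1. Among the measured compounds shown here, the one step that can be read from the data is a chloro in place of methyl on an aromatic carbon, a number 25 percentage points higher from compound 2 to compound 3 (beyond the scatter), a modest rise beyond the scatter.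

Compound 4 `CCC(C(=O)N1CCN(c2ccc(Cl)cc2)CC1)N1C(=O)CCC1=O` has not been measured. It differs from compound 3 in this way: 4-chlorophenyl in place of 3-chlorophenyl on an amine nitrogen in a ring. For the measured compounds named here, no measured step moves a group from one aromatic position to another, so no step bears directly on this change. Compound 4 carries its substituent where compound 1 does, and in this assay compound 1 gives 0%, while compound 3 gives 100%; those two differ in the substituent as well as its place, so they set only a loose boundary. Compound 4 is therefore expected to fall somewhere between them, a number 40 percentage points lower from compound 3 to compound 4 (beyond the scatter), most likely a drop beyond the scatter. The estimate for compound 4 is 60%, within 20% to 100%.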

Compound 4, a percentage reported as activity, at one dose (the size of the read-out at that dose, not a potency): 25%
The estimate for compound 4 lay 35 percentage points above the measured number; the measured number falls inside the stated range.
By their numbers in this assay, from the lowest: compound 1; then compound 4; then compound 2; then compound 3.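

In this assay, among the compounds shown here, the change from 3-chlorophenyl to 4-chlorophenyl leaves the atoms of the group the same and alters only where the chloro sits on the phenyl ring, yet it gives a number 75 percentage points lower from compound 3 to compound 4 (beyond the scatter) and so provides the first direct evidence that this placement matters. The 4-chlorophenyl group also falls well short of the 3-methylphenyl group, with a number 50 percentage points lower from compound 2 to compound 4 (beyond the scatter) as the step, although that comparison changes both the substituent and its place, while chloro in place of trifluoromethyl gives a number 25 percentage points higher from compound 1 to compound 4 (beyond the scatter) and shows that the identity of the substituent still counts when its place on the ring is held constant. No measurement available here explains why moving the chloro has so large an effect.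

The compounds shown do not reveal whether a methyl group would lose as much as the chloro when moved to the place it occupies in compound 4. They also leave open how an unsubstituted phenyl, a fluoro group or a methoxy group would compare on the same shared core.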